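The source may hold more compounds than are shown below. What is called first, only, known or untested is meant among the compounds shown, and "the series" means these compounds.

Measured so far:
compound 1, `CCOC(=O)C(=O)Nc1ccccc(NC)c1=O`, 83%
compound 2, `CC(C)OC(=O)C(=O)Nc1cccccc1=O`, 96%

Of the compounds shown here, two have been measured in a functional assay on the whole organism (strain Sprague-Dawley CD) for inhibition, with Rattus norvegicus as the target, read by paw edema, at a dose of 30 mg/kg by the intraperitoneal route; on this read-out lower numbers stand for a weaker effect and higher numbers for a stronger effect at the one dose given. Compound 1 is `CCOC(=O)C(=O)Nc1ccccc(NC)c1=O` and in this assay compound 1 gives 83%. Compound 2 is `CC(C)OC(=O)C(=O)Nc1cccccc1=O` and in this assay compound 2 gives 96%. Compound 2 stands at the higher of the two numbers; compound 1 lies below it by a gap that is beyond the usual scatter. Among the compounds with values here, the two structures differ in more than one place, so no single step between them is described, and only their two values can be compared.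

The next compound is compound 3, `O=C(Nc1cccccc1=O)C(=O)Oc1ccccc1`. It differs from compound 2 in one place: phenyl in place of isopropyl on an oxygen next to a carbonyl group. Within the data shown here, no step between measured compounds is known for this kind of change, so there is nothing to measure the expectation against. Since compound 2 already stands near the top of the range, compound 3 is estimated to sit at about the same level or a little lower; the expected step is a number 11 percentage points lower from compound 2 to compound 3 (beyond the scatter), a small shift downward that may well lie within the scatter. For compound 3 the estimated inhibition is 85%, with a range from 65% to 98%.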

Compound 3, a percentage reported as inhibition, in the whole organism at one dose (the size of the read-out at that dose, not a potency): 73%
The estimate for compound 3 lay 12 percentage points above the measured number; the range from low to high includes it.
By their numbers in this assay, from the lowest: compounds 3 and 1 (each within the scatter of the next); then compound 2.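

Phenyl in place of isopropyl on an oxygen next to a carbonyl group gives a number 23 percentage points lower from compound 2 to compound 3 (beyond the scatter) in this assay. This is the only single-place step among these compounds, and it shows that the read-out responds to the group at this place, while the exchange for a six-membered aromatic ring of carbon only still leaves compound 3 with a substantial effect of 73% at the one dose given. No available evidence bears on the reason for this step, so it stands as an observation only.

On these data alone, with one step at this place, it remains open whether a longer chain or a benzyl group on the same oxygen would stand nearer to compound 2 or to compound 3, and whether an amine or a carboxylic acid carried there would keep the effect. Since the read-out gives the size of the effect at one dose and not a potency, the step also leaves open how compound 2 and compound 3 would compare at other doses.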